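This account rests on a few compounds, and the source may have more. Where it says the series, first, only, none or still open, it means among the compounds named here.

Measured so far in an assay on HEK293 cells for inhibition of Voltage-dependent T-type calcium channel subunit alpha-1G (Homo sapiens), read by fluorescence, tested at 10 uM; a lower number here means less inhibition, a higher number more inhibition at the concentration tested (going by the name of the read-out):
compound 1 `CCCc1nc(-c2ccccc2)c(CNCCN2CCN(c3ccccc3OC)CC2)o1` gives 39.7%;
compound 2 `CCCc1nc(-c2ccccc2)c(CNCCN2CCN(c3ccc(F)cc3)CC2)o1` gives 54.1%;
compound 3 `CCCc1nc(-c2ccccc2)c(CNCCN2CCN(c3ccccc3C(F)(F)F)CC2)o1` gives 54.6%.

Compound 3 has the highest of these three numbers, but its lead over compound 2 is small: the step of a number 0.5 percentage points higher from compound 2 to compound 3 (within the scatter) lies within the usual scatter, so the two cannot be ranked against each other. Compound 1 sits furthest off, the step of a number 14.9 percentage points higher from compound 1 to compound 3 (beyond the scatter) being beyond the scatter.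

Compound 4 `CCCc1nc(-c2ccccc2)c(CNCCN2CCN(c3cccc(F)c3)CC2)o1` has not yet been measured. It differs from compound 3 in one place: 3-fluorophenyl in place of 2-(trifluoromethyl)phenyl on an amine nitrogen in a ring

Two measured steps speak to this change. The step of a number 0.5 percentage points higher from compound 2 to compound 3 (within the scatter) exchanged one fluorophenyl for the 2-(trifluoromethyl)phenyl group on the same ring nitrogen and moved nothing beyond the scatter; the step of a number 14.4 percentage points higher from compound 1 to compound 2 (beyond the scatter) shows that a fluorophenyl on that nitrogen can sit at the upper end of the three numbers. Going back from the 2-(trifluoromethyl)phenyl group to a fluorophenyl is therefore expected to give a step of a number 3.6 percentage points lower from compound 3 to compound 4 (within the scatter) that stays within the scatter. Compound 4 is estimated at 51% in this assay, with a likely range from 36% to 66%.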

Compound 4, a percentage reported as inhibition, at one concentration (the size of the read-out at that concentration, not a potency): 62.3%
Compound 4: the middle estimate sits 11.3 percentage points below what was measured; the range from low to high includes it.
By their numbers in this assay, from the lowest: compound 1; then compounds 2, 3 and 4 (each within the scatter of the next).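

In this assay, 3-fluorophenyl in place of 4-fluorophenyl gives a number 8.2 percentage points higher from compound 2 to compound 4 (within the scatter), and 3-fluorophenyl in place of 2-(trifluoromethyl)phenyl gives a number 7.7 percentage points higher from compound 3 to compound 4 (within the scatter), so neither swap separates these compounds and the three groups cannot be ranked against one another on this evidence. Against the 2-methoxyphenyl group, the result is a number 22.6 percentage points higher from compound 1 to compound 4 (beyond the scatter), which adds a third group on this ring nitrogen that lies clear of compound 1, so among the four compounds shown, only compound 1 stands apart. Nothing measured here explains why 2-methoxyphenyl differs from the other three groups.

From the compounds shown here alone, what a pyridine ring, a 3-chlorophenyl group or a benzyl group on this same ring nitrogen would give remains open, and so does whether the read-out would respond to such groups at all as it does to the aromatic groups seen so far. Going by these compounds, all four compounds also share the rest of the structure, including the propyl chain, so the effect of a longer chain there is unknown, and a reading at one concentration leaves their potencies undetermined.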